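This account rests on a few compounds, and the source may have more. Where it says the series, first, only, none or still open, it means among the compounds named here.

Working notes on the cytotoxicity series built on the core of compound 1 `CCCCSc1nc(N)nc2c1ncn2/C=C1/CC1(CO)CO`. In an ADME assay on MOLT-3 cells (Homo sapiens) for cytotoxicity, with a stated time of 7 days (on this read-out higher numbers stand for lower toxicity in this test and lower numbers for higher toxicity in this test), compound 1 returns only a limit of the assay, > 20000 nM. Compound 3 `Nc1nc(NC2CCCC2)c2ncn(/C=C3/CC3(CO)CO)c2n1`, which carries cyclopentylamino in place of butylsulfanyl on an aromatic carbon, likewise returns only a limit in this assay, > 20000 nM. The step that the two limits leave unreadable from compound 1 to compound 3 is therefore not readable in size or direction. Among the measured compounds shown here, compound 2 `Nc1nc(NC2CCCCC2)c2ncn(/C=C3/CC3(CO)CO)c2n1` has no result in this assay, the record reading "not determined" (no result reported), so compound 2 stands nowhere on the measured numbers; the only evidence across the series is the limit of > 20000 nM in this assay, at which 2 of the 3 values shown sit.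

Compound 4 `Nc1nc(SC2CCCC2)c2ncn(/C=C3/CC3(CO)CO)c2n1` differs from compound 2 by cyclopentylsulfanyl in place of cyclohexylamino on an aromatic carbon. For the measured compounds named here, no measured step covers a change of this kind, and the sulfanyl-to-amino comparison between compound 1 and compound 3 is mute. The expectation for compound 4 in this assay is no toxicity within range, because the two known values both sit at the limit of > 20000 nM in this assay, at which 2 of the 3 values shown sit. Compound 4 is estimated at 25000 nM, with a range of 10000 nM to 60000 nM, most probably reported again as a limit only.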

Compound 4, half-maximal cytotoxic concentration: > 20000 nM
Compound 4 ended at the assay's limit; the forecaster's own chance of this, stated with the estimate: 80%; the middle value does not contradict the limit.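

No step can be read in this assay from compound 4 to compound 1 or compound 3, since all three results are limits of the assay: the limit of > 20000 nM in this assay, at which 3 of the 4 values shown sit.

The compounds shown leave open at what concentration any of them becomes cytotoxic, and whether butylsulfanyl, cyclopentylamino and cyclopentylsulfanyl differ at all.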